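Cytotoxicity of oxazolidinone analogues: from methoxy to ethylurea

The compounds below may be only part of what the source reports. "The series", "measured", "known", "first", "only" and "open" are said of these compounds alone.

The series shares the core of compound 1 `COC(=O)CC1CCN(C[C@H]2CN(c3ccc(-n4cc(-c5ccccn5)cn4)c(F)c3)C(=O)O2)CC1`, a fluorinated aryl-oxazolidinone bearing a pyridinyl-pyrazole. In an ADME assay on HEK293-A cells (Homo sapiens) for cytotoxicity, read by MTT assay, with a stated time of 48 h (a higher number here means a weaker inhibitor, a lower number a stronger inhibitor), compound 1 gives 224 ug/mL. Compound 2 `COC[C@H]1CN(c2ccc(-n3cc(-c4ccccn4)cn3)c(F)c2)C(=O)O1` carries a methoxy on the saturated chain carbon bound to a saturated ring carbon. In this assay compound 2 reaches only the limit of > 400 ug/mL, so no number is known for it, and (the limit of > 400 ug/mL in this assay, at which 1 of the 2 values shown sits). The step of an at least 1.7-fold higher number from compound 1 to compound 2 (0.25 log units; that floor lies within the scatter) is therefore bounded on one side only, and its floor lies within the scatter.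

Compound 3 `CCNC(=O)NC[C@H]1CN(c2ccc(-n3cc(-c4ccccn4)cn3)c(F)c2)C(=O)O1` has not been measured. It differs from compound 2 by (ethylcarbamoyl)amino in place of methoxy on a saturated chain carbon bound to a saturated ring carbon. Among the measured compounds shown here, the only measured step touches the same place, and it gave no change beyond the scatter while ending at the limit. Compound 3 is therefore expected to show a number no higher from compound 2 to compound 3 (the limit leaves the size open), that is no shift beyond the scatter. The estimate for compound 3 is 400 ug/mL, within a range of 200 ug/mL to 800 ug/mL, with a fair chance that only a limit is reported.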

Compound 3, half-maximal inhibitory concentration: 29 ug/mL
Beside the measured number, compound 3's estimate is 14-fold (1.14 log units) above it, and the stated range ends above it.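

In this assay, among the compounds shown here, the position on the saturated chain carbon bound to a saturated ring carbon now proves sensitive to what it carries: the one earlier step there had a floor within the scatter, whereas (ethylcarbamoyl)amino in place of methoxy gives an at least 13-fold lower number from compound 2 to compound 3 (1.13 log units; beyond the scatter). The same group in place of 4-((methoxycarbonyl)methyl)piperidin-1-yl gives a 7.7-fold lower number from compound 1 to compound 3 (0.89 log units; beyond the scatter), so compound 3 is the strongest inhibitor of the three, with steps beyond the scatter to both other compounds. The true size of the step from the methoxy compound remains unknown, and only its floor can be read, because compound 2 stands at a limit and has no number of its own: the limit of > 400 ug/mL in this assay, at which 1 of the 3 values shown sits.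

The compounds shown do not tell which part of the (ethylcarbamoyl)amino group goes with the lower number, since a plain amine or an acetamide on the same carbon would be needed to separate the ethyl end from the rest of the group. Nor do they show whether a longer chain in place of the ethyl, or a carboxylic acid at this position, would move the number further in either direction.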